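The source may hold more compounds than are shown below. What is called first, only, known or untested is meant among the compounds shown, and "the series" means these compounds.

Of the compounds shown here, two have so far been measured in an ADME assay on HEp-2 cells (Homo sapiens) for cytotoxicity, read by CCK-8 assay, with a stated time of 5 days; on this read-out higher numbers stand for lower toxicity in this test and lower numbers for higher toxicity in this test. Compound 1, `Cc1ccc2nc(N3CCCc4ccc(F)cc4C3)cc(NCC3(N)COC3)c2c1`, reaches only a limit of the assay, > 100000 nM. Its value is the limit of > 100000 nM in this assay, at which 1 of the 2 values shown sits. Compound 2, `NCC(O)CNc1cc(N2CCc3ccccc3C2)nc2ccccc12`, gives 21000 nM in this assay. Compound 2 therefore stands as the only one of the two with an actual number, and no order between the two compounds can be read from a number set against a limit.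

Compound 3, `NCCNc1cc(N2CCc3ccccc3C2)nc2ccccc12`, has not yet been measured in this assay. It differs from compound 2 in a single place: aminomethyl in place of 2-amino-1-hydroxyethyl on a saturated chain carbon bound to a nitrogen on an aromatic ring. Read one bond further out, the side chain changes from 3-amino-2-hydroxypropyl to 2-aminoethyl.

For the measured compounds named here, no measured pair of compounds shows the effect of such a change, so the expectation rests on the size of the change alone. The expected step of a 1.1-fold lower number from compound 2 to compound 3 (0.02 log units; within the scatter) is small, not beyond the usual scatter, with no firm direction. Compound 3 is thus expected to give about 20000 nM in this assay, with a likely range from 7000 nM to 60000 nM.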

Compound 3, half-maximal cytotoxic concentration: 15000 nM
Estimate against measurement, compound 3: 1.3-fold (0.12 log units) above; low and high end bracket the measured number.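

In this assay, putting aminomethyl in place of 2-amino-1-hydroxyethyl on a saturated chain carbon bound to a nitrogen on an aromatic ring gives a 1.4-fold lower number from compound 2 to compound 3 (0.15 log units; within the scatter). This is the first pair shown that differs in one place only, so it gives the first direct reading of this position: with the shared core unchanged, the 3-amino-2-hydroxypropyl and 2-aminoethyl side chains cannot be told apart in this test, even though the hydroxyl group is gone and the group that enters is the smaller of the two. Nothing measured here gives a reason for this result, and a step this small does not call for one.

Going by these compounds, it remains open whether the same holds for a longer chain such as 3-aminopropyl, or for a chain that ends in a dimethylamino group or a carboxylic acid instead of a primary amine. A 2-hydroxyethyl side chain, which keeps a hydroxyl group but has no amine, would show whether the terminal amine matters at this position in this test.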